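Aminomethyl to 1-aminocyclopropyl on the carbonyl of compound 3

The source may report more compounds than this note shows. Statements on the series, on what has been measured and on what is new or still open speak of the compounds shown alone.

Of the compounds shown here, three on the shared core have numbers so far. In a functional assay on NCI-H1975 cells (Homo sapiens) for antiproliferative activity (a higher number here means a weaker inhibitor, a lower number a stronger inhibitor), compound 1 (`Cc1c2c(n3c1CCCN[C@@H](C)[C@H](C)Nc1cc-3ccc1C(N)=O)CC(C)(C)CC2=O`) gives 20 nM and compound 2 (`CC(=O)N1CCCc2c(C)c3c(n2-c2ccc(C(N)=O)c(c2)N[C@@H](C)[C@@H]1C)CC(C)(C)CC3=O`) gives 20 nM. In this assay compound 3 (`Cc1c2c(n3c1CCN(C(=O)CN)C[C@@H](C)[C@H](C)Nc1cc-3ccc1C(N)=O)CC(C)(C)CC2=O`) gives 190 nM, the highest of the three numbers and the weakest inhibitor of the set, with both other values lying beyond the scatter from it.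

The next structure is compound 4 (`Cc1c2c(n3c1CCN(C(=O)C1(N)CC1)C[C@@H](C)[C@H](C)Nc1cc-3ccc1C(N)=O)CC(C)(C)CC2=O`). The change is 1-aminocyclopropyl in place of aminomethyl on a carbonyl carbon, whose other neighbour is an amide-type nitrogen in a ring.

Going by the values given here, only one measured step is available, no change at the digits printed from compound 1 to compound 2 (within the scatter), with acetyl in place of hydrogen on an amine nitrogen in a ring. Among the compounds with values here, it bears only loosely on this change, since no measured pair alters the group on that carbonyl carbon. With that single step as the guide, no shift beyond the scatter is expected in this assay, and neither direction is favoured. The expected step is a 1.3-fold lower number from compound 3 to compound 4 (0.10 log units; within the scatter). The direct evidence is thin, so the range is kept wide. For compound 4 the estimated value is 150 nM, with an expected range of 50 nM to 450 nM.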

Compound 4, half-maximal inhibitory concentration: 72 nM
Beside the measured number, compound 4's estimate is 2.1-fold (0.32 log units) above it; the measured number falls inside the stated range.
By their numbers in this assay, from the lowest: compounds 1 and 2 (each within the scatter of the next); then compound 4; then compound 3.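

In this assay, the group on the carbonyl carbon whose other neighbour is an amide-type nitrogen in a ring can move the number: 1-aminocyclopropyl in place of aminomethyl gives a 2.6-fold lower number from compound 3 to compound 4 (0.42 log units; beyond the scatter). Going by these compounds alone, the only earlier step, no change at the digits printed from compound 1 to compound 2 (within the scatter), was acetyl in place of hydrogen on an amine nitrogen in a ring, so it gave no sign that this carbonyl substituent would respond to a change. No supporting measurement accompanies this result, so the step stands as an observation without an explanation.

The compounds shown leave open whether the three-membered ring of carbon matters as a ring, since how 1-aminocyclobutyl or 2-aminoethyl on the same carbonyl carbon would read against compound 4 at 72 nM is unknown. Also open, from the compounds shown here alone, is whether the amine on this group is needed at all, a question that a plain cyclopropyl group at the same place would address.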